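A Methoxy for an Ethyl: Expected Cytotoxicity of Compound 4

The compounds below may be only part of what the source reports. "The series", "measured", "known", "first", "only" and "open" are said of these compounds alone.

Compound 1, `CCc1ccc2[nH]c(=O)c(CN(Cc3ccc(C(C)(C)C)cc3)Cc3ccc(F)c(F)c3)cc2c1`: in a toxicity assay on MDCK cells (Canis lupus familiaris) for cytotoxicity, read by crystal violet staining, with a stated time of 48 h (on this read-out higher numbers stand for lower toxicity in this test and lower numbers for higher toxicity in this test), compound 1 gives > 33000 nM, which is a limit of the assay and not a number.
Compound 2, `CCc1ccc2[nH]c(=O)c(CN(Cc3ccc(C(C)(C)C)cc3)[C@@H](C)c3ccc(F)cc3)cc2c1`: in this assay compound 2 gives > 5000 nM, again a limit.
Compound 3, `CCc1ccc2[nH]c(=O)c(CN(Cc3ccc(C(C)(C)C)cc3)[C@@H](C)c3ccc(OC)cc3)cc2c1`: in this assay compound 3 gives > 5000 nM, likewise a limit.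

Compound 3 therefore stands only at a limit, as do the two other measured compounds. The three steps among the measured compounds, a step that the two limits leave unreadable from compound 1 to compound 2, a step that the two limits leave unreadable from compound 1 to compound 3 and a step that the two limits leave unreadable from compound 2 to compound 3, cannot be read in size or direction, since each pair rests on the limit of > 33000 nM in this assay, at which 1 of the 3 values shown sits, or (the limit of > 5000 nM in this assay, at which 2 of the 3 values shown sit).

Compound 4, `COc1ccc([C@H](C)N(Cc2ccc(C(C)(C)C)cc2)Cc2cc3cc(OC)ccc3[nH]c2=O)cc1`, differs from compound 3 by methoxy in place of ethyl on an aromatic carbon. Among the measured compounds shown here, no measured step touches this position of the shared core, and the steps that exist are unreadable, so none of them bears on the change in a readable way. The expected step from compound 3 to compound 4 is accordingly a step that the limit leaves unreadable from compound 3 to compound 4, with no reason to expect a movement beyond the scatter. For compound 4 the estimate in this assay is 20000 nM, within a range of 5000 nM to 100000 nM, and most likely the assay again reports only a limit.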

Compound 4, half-maximal cytotoxic concentration: 4100 nM
For compound 4 the middle estimate is 4.9-fold (0.69 log units) above the measured one; measured number outside the range, below it.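

With methoxy in place of ethyl on this aromatic carbon, compound 4 gives 4100 nM in this assay, the first actual number among the compounds shown and the first measurement of any change at this position of the shared core. Compound 3 gives > 5000 nM, which is a limit of the assay and not a number. The change therefore reads only as an at least 1.2-fold lower number from compound 3 to compound 4 (0.08 log units; that floor lies within the scatter), which does not by itself establish a movement beyond the scatter, and its full size stays unread because compound 3 stands at a limit: the limit of > 5000 nM in this assay, at which 2 of the 4 values shown sit.

From the compounds shown here alone, the steps among compound 1, compound 2 and compound 3 cannot be read, so it remains open whether the change from ethyl to methoxy would have the same effect with the other groups on the amine nitrogen, such as the 3,4-difluorobenzyl of compound 1. Going by these compounds, it is also open how other groups on this aromatic carbon, such as an amine, a carboxylic acid or a longer chain, would read in this assay.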